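Thiophen-2-yl to pyrrolidin-1-yl on a carbonyl carbon

The compounds below may be only part of what the source reports. "The series", "measured", "known", "first", "only" and "open" are said of these compounds alone.

Compound 1 `O=C(Nc1ccc2sc(-c3ccccc3)nc2c1)c1cccs1`: > 50 uM (a limit)
Compound 2 `O=C(Nc1ccc2sc(-c3ccccc3)nc2c1)N1CCCCC1`: > 50 uM (a limit)
Compound 3 `O=C(Nc1ccc2sc(-c3ccc(F)c(F)c3)nc2c1)N1CCCCC1`: > 50 uM (a limit)

In an ADME assay on HepG2 cells (Homo sapiens) for inhibition, read by resazurin assay, with a stated time of 48 h (on this read-out lower numbers stand for an effect already at smaller amounts and higher numbers for an effect only at larger amounts of compound), compound 1 stands at > 50 uM (a limit of the assay, not a number). It has no measured neighbour to be ranked against, as the data show (the limit of > 50 uM in this assay, at which 3 of the 3 values shown sit).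

Compound 4 `O=C(Nc1ccc2sc(-c3ccccc3)nc2c1)N1CCCC1` keeps the core of compound 1 and changes one group: pyrrolidin-1-yl in place of thiophen-2-yl on a carbonyl carbon. The nearest measured change is a step that the two limits leave unreadable from compound 1 to compound 2, with piperidin-1-yl in place of thiophen-2-yl on a carbonyl carbon. The other is a step that the two limits leave unreadable from compound 2 to compound 3, with 3,4-difluorophenyl in place of phenyl on an aromatic carbon. Among the measured compounds shown here, neither gives a size, so no step of definite size or direction is expected in this assay, and a further limit is the likeliest report. For compound 4 the estimated value is 60 uM, with an expected range from 35 uM to 100 uM. The expected change is a step that the limit leaves unreadable from compound 1 to compound 4.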

Compound 4, concentration for 90% of the maximal effect: > 50 uM
Compound 4 ended at the assay's limit; the forecaster's own chance of this, stated with the estimate: 85%; the middle value does not contradict the limit.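

Compound 4 gives no readable step against compound 1 or compound 2, because in this assay all of these compounds sit at a limit of the assay, not at a number: the limit of > 50 uM in this assay, at which 4 of the 4 values shown sit.

The compounds shown leave open whether pyrrolidin-1-yl, piperidin-1-yl or thiophen-2-yl on the carbonyl carbon makes any difference in this read-out.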